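Swapping the Aryl Group: Expected Cytotoxicity of Compound 3

The compounds below may be only part of what the source reports. "The series", "measured", "known", "first", "only" and "open" are said of these compounds alone.

compound 1, `Cc1ccc(C2C(C#N)=C(N)N(c3ccc(S(N)(=O)=O)cc3)C3=C2CCCC3)cc1`: 30%
compound 2, `N#CC1=C(N)N(c2ccc(S(N)(=O)=O)cc2)C2=C(CCCC2)C1c1ccc(Cl)cc1Cl`: 50%

In a functional assay on Ehrlich cells (Mus musculus) for cytotoxicity, read by trypan blue exclusion, with a stated time of 2 h, tested at 25 ug/mL (a lower number here means a weaker effect, a higher number a stronger effect of the compound at the concentration tested), compound 1 gives 30% and compound 2 gives 50%. Within the data shown here, compound 2 holds the higher of the two numbers, and the single measured step, a number 20 percentage points higher from compound 1 to compound 2 (beyond the scatter), is what separates them. Compound 3 `N#CC1=C(N)N(c2ccc(S(N)(=O)=O)cc2)C2=C(CCCC2)C1c1cccs1` differs from compound 2 by thiophen-2-yl in place of 2,4-dichlorophenyl on a saturated ring carbon. Among the measured compounds shown here, no measured step involves a thiophen-2-yl group, so the one known step at this saturated ring carbon bears on the present change only loosely. As that step was modest, a modest move is expected here as well, back toward the number of compound 1. Compound 3 is therefore estimated at 35% (range 15% to 55%). The expected step is a number 15 percentage points lower from compound 2 to compound 3 (beyond the scatter).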

Compound 3, a percentage reported as activity, at one concentration (the size of the read-out at that concentration, not a potency): 5%
Compound 3: the middle estimate sits 30 percentage points above what was measured; the measured number lies below the stated range.
By their numbers in this assay, from the lowest: compound 3; then compound 1; then compound 2.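

In this assay, the saturated ring carbon proves to work in both directions: a number 45 percentage points lower from compound 2 to compound 3 (beyond the scatter) and a number 25 percentage points lower from compound 1 to compound 3 (beyond the scatter), which places thiophen-2-yl under both groups with a six-membered aromatic ring rather than between them. The earlier pair had shown only a rise on moving to 2,4-dichlorophenyl. No evidence at hand accounts for this drop. Going by these compounds, whether it follows the five-membered ring, the sulfur or the loss of chlorine stays open, as compound 3 changes all of these at once. An unsubstituted phenyl or a furan-2-yl group at this carbon would help to separate them.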